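From 4-nitrophenyl to 2,3,4-trifluorophenyl at the limit

A few compounds are considered here, and "the series" means these few. Any claim that something is new, unique, unknown or untested is made for them only; others in the source may bear on it.

Compound 1 `O=C1/C(=C/c2ccc(Cl)c(Cl)c2)SC(=S)N1NS(=O)(=O)c1cccs1` limit > 100000 nM
Compound 2 `O=C1/C(=C/c2ccc([N+](=O)[O-])cc2)SC(=S)N1NS(=O)(=O)c1ccccc1` limit > 100000 nM
Compound 3 `O=C1/C(=C/c2ccc(C(F)(F)F)cc2)SC(=S)N1NS(=O)(=O)c1ccccc1` limit > 100000 nM

In a functional assay on HFF cells (Homo sapiens) for cytotoxicity (on this read-out higher numbers stand for weaker inhibition and lower numbers for stronger inhibition), compound 2 gives only a limit, not a number, at > 100000 nM. The measured set offers (the limit of > 100000 nM in this assay, at which 3 of the 3 values shown sit). Compound 4 `O=C1/C(=C/c2ccc(F)c(F)c2F)SC(=S)N1NS(=O)(=O)c1ccccc1` differs from compound 2 as follows: 2,3,4-trifluorophenyl in place of 4-nitrophenyl on a double-bonded chain carbon bound to a double-bonded ring carbon. In words, 2,3,4-trifluorophenyl replaces 4-nitrophenyl on a double-bonded chain carbon bound to a double-bonded ring carbon. Among the measured compounds shown here, the one measured step at this aryl group is a step that the two limits leave unreadable from compound 2 to compound 3, and it gives no size to carry over. No step beyond the scatter is therefore expected in this assay, and no direction. The estimate is a number no higher from compound 2 to compound 4 (the limit leaves the size open). For compound 4 the expected value is 100000 nM, within an estimated range from 40000 nM to 250000 nM.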

Compound 4, half-maximal inhibitory concentration: > 100000 nM
Compound 4 was reported as a limit; the forecaster's own chance of this, stated with the estimate: 85%; the middle value lies on the limit itself.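

In this assay compound 4 gives > 100000 nM, a limit and not a number. Among the compounds shown here, compound 2 is likewise only a limit, so no step between compound 2 and compound 4 can be read. The compounds shown leave open whether their aryl groups differ at all in this read-out.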